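The source may report more compounds than this note shows. Statements on the series, on what has been measured and on what is new or still open speak of the compounds shown alone.

In an ADME assay on Vero cells (Chlorocebus sabaeus) for cytotoxicity, read by CellTiter-Glo, with a stated time of 72 h (a higher number here means that more compound is tolerated, a lower number that less compound is tolerated), compound 3 `CCOC(=O)Nc1nc(NC(C)CCCN(CC)CC)c2c(n1)SC(c1ccccc1)C(c1ccccc1)=N2` gives > 40000 nM, which is a limit rather than a number. Compound 1 `CCOC(=O)Nc1cc(NC(C)CCCN(CC)CC)c2nc(-c3cccs3)c(-c3cccs3)nc2n1` gives the same limit, > 40000 nM. Going by the values given here, compound 2 `CCOC(=O)Nc1cc(NCCN(C)C)c2nc(-c3cccs3)c(-c3cccs3)nc2n1` gives 1600 nM, and the single measured step, an at least 25-fold lower number from compound 1 to compound 2 (1.39 log units; beyond the scatter), concerns a different change on the same aromatic nitrogen, so it bears only loosely on the present case. Compound 4 `CCOC(=O)Nc1nc(NCCCCN(CC)CC)c2c(n1)SC(c1ccccc1)C(c1ccccc1)=N2` differs from compound 3 by hydrogen in place of methyl on a saturated chain carbon bound to a nitrogen on an aromatic ring and a saturated chain carbon. Among the compounds with values here, no measured step follows this small change, and compound 3 already sits at the limit described by the limit of > 40000 nM in this assay, at which 2 of the 3 values shown sit, so no step beyond the scatter is expected in this assay, namely a number no higher from compound 3 to compound 4 (the limit leaves the size open). Compound 4 is therefore expected to give about 40000 nM, within 10000 nM to 100000 nM, most probably again reported only as a limit.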

Compound 4, half-maximal cytotoxic concentration: > 40000 nM
Compound 4 was reported as a limit; the forecaster's own chance of this, stated with the estimate: 65%; the middle value lies on the limit itself.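

In this assay, compound 3 and compound 4 are both reported only as limits, so no step can be read between them: the limit of > 40000 nM in this assay, at which 3 of the 4 values shown sit. On these data alone, whether hydrogen in place of methyl on this chain changes the tolerated concentration at all remains open.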